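The compounds below may be only part of what the source reports. "The series", "measured", "known", "first", "only" and "open" are said of these compounds alone.

Of the compounds shown here, two built on one shared core have been measured in a functional assay on NCI-H3122 cells (Homo sapiens) for antiproliferative activity, read by MTT assay, with a stated time of 48 h; on this read-out higher numbers stand for weaker inhibition and lower numbers for stronger inhibition. Compound 1, with the structure `CC(Oc1cccnc1Nc1cnn(C)c1)c1cccc(C(=O)NCc2ccc(Cl)c(C(F)(F)F)c2)c1`, gives 50700 nM in this assay. Compound 2, with the structure `COc1ccc(CNC(=O)c2cccc(C(C)Oc3ccnc(Nc4cnn(C)c4)c3)c2)cc1OC`, gives 38500 nM in this assay. Of these two numbers, that of compound 2 is the lower one, but the number of compound 1 sits so close to it that the gap lies within the usual scatter of repeated measurements, so the two compounds cannot be ranked against each other on this evidence.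

The next compound, compound 3, has the structure `Cc1ccc(CNC(=O)c2cccc(C(C)Oc3ccnc(Nc4cnn(C)c4)c3)c2)cc1`. Compared with compound 2, the change is 4-methylphenyl in place of 3,4-dimethoxyphenyl on a saturated chain carbon bound to an amide-type nitrogen. Going by the values given here, no measured pair in this small set shows what such a swap does to the read-out, so there is no comparable step to lean on; what the two measured compounds share is a weak read-out. On that basis, compound 3 is expected to stay in the same weak region, with a step of a 1.1-fold higher number from compound 2 to compound 3 (0.04 log units; within the scatter) that is not expected to go clearly beyond the scatter in either direction. The estimate for compound 3 in this assay is therefore 42000 nM, with a likely range from 15000 nM to 110000 nM.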

Compound 3, half-maximal inhibitory concentration: 7700 nM
For compound 3 the middle estimate is 5.5-fold (0.74 log units) above the measured one; measured number outside the range, below it.
By their numbers in this assay, from the lowest: compound 3; then compounds 2 and 1 (each within the scatter of the next).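

In this assay, going by these compounds alone, the position on a saturated chain carbon bound to an amide-type nitrogen now shows that it is not indifferent to the group it carries: 4-methylphenyl in place of 3,4-dimethoxyphenyl gives a 5.0-fold lower number from compound 2 to compound 3 (0.70 log units; beyond the scatter), a modest step, but the first single change here that stands clear of the scatter. The direction is towards stronger inhibition, and it comes with the group that has fewer heavy atoms and 0 hydrogen-bond acceptors, where the group that leaves has 2. Nothing measured here explains why this swap lowers the number.

The change removes two methoxy groups and adds one methyl in a single step, so these compounds cannot show whether the lower number comes from losing the methoxy groups, from gaining the methyl, or from both. A plain phenyl ring, a ring with a single methoxy group, or an ethyl group or a chlorine atom in place of the methyl would be needed to separate these possibilities and to show how far this position can go.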